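Thiophen-2-yl in Place of Phenyl on a Shared Core

A few compounds are considered here, and "the series" means these few. Any claim that something is new, unique, unknown or untested is made for them only; others in the source may bear on it.

Compound 1 `COc1cc(-c2cccc3nc(-c4ccccc4)oc23)cc(OC)c1OC` gives in a functional assay on MCF7 cells (Homo sapiens) for antiproliferative activity, read by MTT assay, with a stated time of 48 h (on this read-out higher numbers stand for weaker inhibition and lower numbers for stronger inhibition), only the limit > 25000 nM.
Compound 2 `COc1ccc(-c2nc3cccc(-c4cc(OC)c(OC)c(OC)c4)c3o2)cc1` gives in this assay only the limit > 25000 nM.
Compound 3 `COc1cc(-c2cccc3nc(-c4cccc(N)c4)oc23)cc(OC)c1OC` gives in this assay only the limit > 25000 nM.

Compound 1 thus stands at the limit of this assay, and no number is known for it; the other two measured compounds stand at the same limit, so all three values share one line: the limit of > 25000 nM in this assay, at which 3 of the 3 values shown sit. For the measured compounds named here, none of the measured steps can be read: the step that the two limits leave unreadable from compound 1 to compound 2 is unreadable, the step that the two limits leave unreadable from compound 1 to compound 3 is unreadable, and the step that the two limits leave unreadable from compound 2 to compound 3 is unreadable as well.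

Compound 4 `COc1cc(-c2cccc3nc(-c4cccs4)oc23)cc(OC)c1OC` differs from compound 1 in one place: thiophen-2-yl in place of phenyl on an aromatic carbon. Going by the values given here, no measured step involves a change at this position, so nothing among the measured compounds speaks directly to the exchange. What the measured compounds do show is that neither a methoxy nor an amino at the ring that is here exchanged, nor the exchange of that ring itself, has moved any compound off the limit. The expected step of a number no higher from compound 1 to compound 4 (the limit leaves the size open) is therefore without a readable size, and compound 4 is expected most likely to reach the same limit once more.

Compound 4 is estimated at 25000 nM, in the range 8000 nM to 60000 nM.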

Compound 4, half-maximal inhibitory concentration: > 25000 nM
Compound 4 ended at the assay's limit (the forecaster's own chance of this, stated with the estimate: 75%); the middle value lies on the limit itself.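

In this assay compound 4 gives > 25000 nM, which is a limit and not a number. None of its steps to compound 1, compound 2 or compound 3 can be read, as all four compounds sit on one line: the limit of > 25000 nM in this assay, at which 4 of the 4 values shown sit. The compounds shown leave open how strongly any of them inhibits, and whether any exchange at this position would give a readable value.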